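Removing the hydroxy from compound 3: a step in lipophilicity

A few compounds are considered here, and "the series" means these few. Any claim that something is new, unique, unknown or untested is made for them only; others in the source may bear on it.

Measured compounds:
compound 1 `O=C(O)COc1ccc([C@H]2CC[C@]3(CC2)OOC2(O3)C3CC4CC(C3)CC2C4)cc1C(=O)O` 1.9
compound 2 `O=C(O)c1ccc([C@H]2CC[C@]3(CC2)OOC2(O3)C3CC4CC(C3)CC2C4)cc1` 3
compound 3 `O=C(O)c1cc([C@H]2CC[C@]3(CC2)OOC2(O3)C3CC4CC(C3)CC2C4)ccc1O` 3

In a physicochemical assay for lipophilicity, read by HPLC, at pH 7.4 (a lower number here means a more polar compound, a higher number a more lipophilic compound), compound 3 gives 3, level with compound 2 at the digits shown, and the two together stand highest of the three numbers. Going by the values given here, compound 1 gives 1.9, the lowest; the only single-place step measured, a number 1.10 log units higher from compound 1 to compound 3 (beyond the scatter), is large and lies beyond the scatter.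

Compound 4 `O=C(O)c1cccc([C@H]2CC[C@]3(CC2)OOC2(O3)C3CC4CC(C3)CC2C4)c1` differs from compound 3 in one place: hydrogen in place of hydroxy on an aromatic carbon. Among the compounds with values here, no measured step removes a hydroxy from the shared core, so the step from compound 1 to compound 3 bears only loosely, showing that taking a polar group off the aromatic ring of this core raised the number. Compound 2, which carries no hydroxy, sits level with compound 3, which suggests the hydroxy costs little here. Compound 4 is therefore expected to land a modest step above compound 3, a number 0.40 log units higher from compound 3 to compound 4 (beyond the scatter), possibly within the scatter. The estimate for compound 4 is 3.4, ranging from 2.9 to 3.9.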

Compound 4, distribution coefficient: 3
Beside the measured number, compound 4's estimate is 0.40 log units above it; low and high end bracket the measured number.
By their numbers in this assay, from the lowest: compound 1; then compounds 2, 3 and 4 (each within the scatter of the next).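

In this assay, hydrogen in place of hydroxy, on the aromatic carbon ortho to a carboxy group and para to a large group, gives no change at the digits printed from compound 3 to compound 4 (within the scatter), so this position tolerates losing the hydroxy with no readable shift. Exchanging 4-carboxyphenyl for 3-carboxyphenyl on the saturated ring carbon likewise gives no change at the digits printed from compound 2 to compound 4 (within the scatter), whereas hydrogen in place of carboxymethoxy on an aromatic carbon gives a number 1.10 log units higher from compound 1 to compound 4 (beyond the scatter), so among these compounds only that last change moves the number. Nothing at hand accounts for these readings.

Going by these compounds, whether a methoxy or an amine at the hydroxy position would also leave the number in place remains open. So does the outcome of exchanging the carboxylic acid for an amide on the shared core.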